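The compounds below may be only part of what the source reports. "The series", "measured", "known", "first", "only" and "open" are said of these compounds alone.

Measured compounds:
compound 1 `Cc1ccc(-c2ccccc2NCC2=NCCN2)n1C`: 78%
compound 2 `CCn1ccc(-c2ccccc2NCC2=NCCN2)n1`: 78%

Of the compounds shown here, two have been measured in a functional assay with Alpha-1A adrenergic receptor (Homo sapiens) as the target, read by calcium flux; on this read-out lower numbers stand for smaller maximal responses and higher numbers for larger maximal responses. Compound 1 reaches 78%. Compound 2, which shares the same core but carries a different five-membered ring at the end, reaches 78%. The two values are level at the digits shown, and the gap between them lies within the usual scatter of such measurements, so nothing can be said about one being larger than the other.

Compound 3 `Cn1cccc1-c1ccccc1NCC1=NCCN1` has not yet been measured. It differs from compound 1 in a single place: hydrogen in place of methyl on an aromatic carbon. Within the data shown here, no pair of measured compounds differs in this way, so there is no measured step to lean on. Among the measured compounds shown here, since the one comparison available, between compound 1 and compound 2, shows no change beyond the scatter when the five-membered ring is altered, the change from compound 1 to compound 3 is expected to be small, in no particular direction, and not beyond the scatter.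

For compound 3 the expected maximal response in this assay is 77%, with a range from 60% to 92%, which means an expected step of a number 1 percentage points lower from compound 1 to compound 3 (within the scatter).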

Compound 3, largest response reached (reported as maximal response), in percent of the reference or control that the assay uses: 103%
Compound 3: middle estimate off by 26 percentage points, on the low side; the whole stated range lies below it.
By their numbers in this assay, from the lowest: compounds 1 and 2 (each within the scatter of the next); then compound 3.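

Taking away the methyl group from this aromatic carbon of the five-membered ring, next to the ring nitrogen and two ring bonds from the ring atom that bears a large group, is not a silent change: in this assay the result is a number 25 percentage points higher from compound 1 to compound 3 (beyond the scatter) on the strength of this one replacement. Among these compounds, no earlier pair differed at this position alone, so this is the first sign that the maximal response depends on what sits on this carbon, and that hydrogen in place of methyl, a change of a single heavy atom, is enough to move it beyond the scatter. Nothing in the data shown offers a reason for this step.

The compounds shown leave open how other groups on this carbon, such as an ethyl group, a chlorine atom or a methoxy group, would compare with hydrogen and methyl. From the compounds shown here alone, this change has also been read only once, so it remains open whether the same replacement would give a similar step on a different core.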